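This account rests on a few compounds, and the source may have more. Where it says the series, first, only, none or still open, it means among the compounds named here.

Measured compounds:
Compound 1 `Clc1ccc(Nc2nc(-c3ccccn3)cs2)nc1` gives < 10000 nM in a physicochemical assay for solubility, in phosphate buffer, with a stated time of 2 h, at pH 7.4 (a lower number here means a less soluble compound, a higher number a more soluble compound), which is a limit of the assay.
Compound 2 `COc1cccc(-c2csc(Nc3ccc(Cl)cn3)n2)n1` gives < 10000 nM in this assay, again a limit of the assay.
Compound 3 `Clc1ccc(Nc2nc(-c3ccccn3)c(Cl)s2)nc1` gives < 10000 nM in this assay, also a limit of the assay.

In prose: the step that the two limits leave unreadable from compound 1 to compound 2 carries the change (methoxy in place of hydrogen on an aromatic carbon), and the step that the two limits leave unreadable from compound 1 to compound 3 carries the change (chloro in place of hydrogen on an aromatic carbon), which is also how the core of compound 3 differs from the core of compound 1. Neither step size can be read because of the limit of < 10000 nM in this assay, at which 3 of the 3 values shown sit.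

Compound 4 `COc1ccc(-c2nc(Nc3ccc(Cl)cn3)sc2Cl)nc1` is not yet measured. Its change from compound 3, (methoxy in place of hydrogen on an aromatic carbon), is the same kind of change as that from compound 1 to compound 2, though the place differs: here the methoxy enters two atoms from the ring nitrogen and para to a large group, whereas in compound 2 it is next to the ring nitrogen and meta to a large group. Beside the unreadable measured step, the step from compound 3 to compound 4 is expected to be a step that the limit leaves unreadable from compound 3 to compound 4, resting on compound 3 and the limit (the limit of < 10000 nM in this assay, at which 3 of the 3 values shown sit). Compound 4 is therefore estimated to give 3000 nM in this assay.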

Compound 4, solubility: < 10000 nM
Compound 4: a limit, no number; the forecaster's own chance of this, stated with the estimate: 80%; the middle value lies beyond the limit too.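

Compound 4 gives < 10000 nM in this assay, which is a limit of the assay. The step from compound 3 to compound 4 therefore cannot be read: the limit of < 10000 nM in this assay, at which 4 of the 4 values shown sit. The compounds shown leave open how large any of these steps is in this assay, whether for methoxy or for chloro in place of hydrogen.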